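The source may report more compounds than this note shows. Statements on the series, on what has been measured and on what is new or still open speak of the compounds shown alone.

Measured in an ADME assay on BJ cells (Homo sapiens), read by MTT assay, with a stated time of 3 days; on this read-out lower numbers stand for stronger inhibition and higher numbers for weaker inhibition:
- Compound 1 `CN(C)c1ncnc2[nH]cc(Sc3cccs3)c12`: 145000 nM
- Compound 2 `Nc1ncnc2[nH]cc(Sc3cccs3)c12`: > 150000 nM
- Compound 3 `Cc1ncnc2[nH]cc(Sc3cccs3)c12`: > 150000 nM

Compound 3 gives > 150000 nM, which is a limit of the assay and not a number. It shares this with compound 2: the limit of > 150000 nM in this assay, at which 2 of the 3 values shown sit.

Compound 4 `COc1ncnc2[nH]cc(Sc3cccs3)c12` carries methoxy in place of methyl on an aromatic carbon.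

Among the compounds with values here, earlier swaps on that same carbon offer the only guide. They give an at least 1.0-fold higher number from compound 1 to compound 2 (0.01 log units; that floor lies within the scatter), an at least 1.0-fold higher number from compound 1 to compound 3 (0.01 log units; that floor lies within the scatter) and a step that the two limits leave unreadable from compound 2 to compound 3, so none shows a change beyond the scatter.

The expected result is a number no higher from compound 3 to compound 4 (the limit leaves the size open), with no real change in this assay anticipated.

The estimate for compound 4 is 150000 nM, within an expected range of 90000 nM to 250000 nM.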

Compound 4, half-maximal inhibitory concentration: 123000 nM
Compound 4: the middle estimate sits 1.2-fold (0.09 log units) above what was measured, within the range that was stated.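

In this assay, within the data shown here, compound 4, with methoxy on this carbon, gives 123000 nM, a number and not a limit of the assay, so compound 1 no longer holds the only number at this position. Among these compounds, the one step between two numbers is a 1.2-fold lower number from compound 1 to compound 4 (0.07 log units; within the scatter), so methoxy and dimethylamino cannot be told apart here. The steps of an at least 1.2-fold lower number from compound 3 to compound 4 (0.08 log units; that floor lies within the scatter) and an at least 1.2-fold lower number from compound 2 to compound 4 (0.08 log units; that floor lies within the scatter) start from limits, and neither shows a real change; two compounds still give no number: the limit of > 150000 nM in this assay, at which 2 of the 4 values shown sit.

Going by these compounds, whether a carboxylic acid or a longer chain on this carbon would give a clearly lower number stays open.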